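A Smaller Saturated Ring, Little Change Expected

The source may report more compounds than this note shows. Statements on the series, on what has been measured and on what is new or still open speak of the compounds shown alone.

Compound 1, `O=C(Nc1ccc(CN2CCCC2)cc1)Nc1ccc2ncnc(Nc3cccc(C(F)(F)F)c3)c2c1`, in a functional assay on A549 cells (Homo sapiens) for antiproliferative activity, read by MTT assay, with a stated time of 72 h (a higher number here means a weaker inhibitor, a lower number a stronger inhibitor), gives 830 nM.
Compound 2, `O=C(Nc1cccc(CN2CCCCC2)c1)Nc1ccc2ncnc(Nc3cccc(C(F)(F)F)c3)c2c1`, in this assay gives 1060 nM.

Among the measured compounds shown here, both compounds share the same core and differ only in the group carried on the phenyl urea and where that group sits; no single-change step links them, so only their two values can be compared. In this assay compound 2 has the higher of the two numbers, but its distance from compound 1 is within the scatter of repeated measurements, so nothing separates them with confidence.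

Compound 3, `O=C(Nc1cccc(CN2CCCC2)c1)Nc1ccc2ncnc(Nc3cccc(C(F)(F)F)c3)c2c1`, has not yet been measured in this assay. It differs from compound 2 in one place: pyrrolidin-1-yl in place of piperidin-1-yl on a saturated chain carbon bound to an aromatic carbon. The saturated ring simply loses one carbon, keeping its single nitrogen and its single hydrogen-bond acceptor.

For the measured compounds named here, with no measured step of this kind to lean on, the step of a 1.1-fold lower number from compound 2 to compound 3 (0.05 log units; within the scatter) is expected to be small, with no direction beyond the scatter. Compound 3 is therefore estimated at 950 nM, with a range from 400 nM to 2300 nM.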

Compound 3, half-maximal inhibitory concentration: 860 nM
The estimate for compound 3 lay 1.1-fold (0.04 log units) above the measured number; measured number inside the range.
By their numbers in this assay, from the lowest: compounds 1, 3 and 2 (each within the scatter of the next).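

In this assay, pyrrolidin-1-yl in place of piperidin-1-yl on a saturated chain carbon bound to an aromatic carbon gives a 1.2-fold lower number from compound 2 to compound 3 (0.09 log units; within the scatter), so this first direct test of the ring swap does not separate the two rings. Among the compounds shown here, compound 3 also supplies the first single-change comparison of where the side group sits, since 3-((pyrrolidin-1-yl)methyl)phenyl in place of 4-((pyrrolidin-1-yl)methyl)phenyl on an amide-type nitrogen gives a 1.0-fold higher number from compound 1 to compound 3 (0.02 log units; within the scatter), and this step does not separate the two placements either. No other data here bear on these two results, so the values can only be reported, not explained.

For the compounds shown here, these steps cover only two saturated rings and two placements, so they cannot say whether a morpholin-4-yl ring, which adds an oxygen atom, or an open-chain dimethylamino group on the same carbon would also leave the number within the scatter. Also open, going by these compounds, are a longer chain linking the pyrrolidin-1-yl ring to the phenyl and whether the 4-((piperidin-1-yl)methyl)phenyl group would match its 3-substituted counterpart in compound 2.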